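Swapping Methoxy for Dimethylamino: Solubility Outlook

This account rests on a few compounds, and the source may have more. Where it says the series, first, only, none or still open, it means among the compounds named here.

Compound 1, `Cc1ccc(-c2cnn3c(NCc4ccccn4)cc(C)nc23)cc1`: < 5000 nM
Compound 2, `COc1ccc(-c2cnn3c(NCc4ccccn4)cc(C)nc23)cc1`: < 5000 nM

In a physicochemical assay for solubility, read by HPLC, using the shake flask method, measured as kinetic solubility, with a stated time of 2 h, at pH 7.4 (on this read-out higher numbers stand for higher solubility and lower numbers for lower solubility), compound 2 gives < 5000 nM, which is a limit of the assay rather than a number. Compound 1 likewise sits at a limit, so the step that the two limits leave unreadable from compound 1 to compound 2 cannot be read. Compound 3, `Cc1cc(NCc2ccccn2)n2ncc(-c3ccc(N(C)C)cc3)c2n1`, differs from compound 2 by dimethylamino in place of methoxy on an aromatic carbon. Within the data shown here, no measured step bears on this change, and both values shown sit at the limit of < 5000 nM in this assay, at which 2 of the 2 values shown sit. Compound 3 is therefore expected to stay near that limit, with an estimated step that the limit leaves unreadable from compound 2 to compound 3. In this assay compound 3 is estimated at 3000 nM, with a range from 500 nM to 15000 nM.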

Compound 3, solubility: < 5000 nM
Compound 3 gave a limit, no number (the forecaster's own chance of this, stated with the estimate: 70%); the middle value lies beyond the limit too.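

In this assay compound 3 gives < 5000 nM, a limit of the assay and not a number. No step among compound 1, compound 2 and compound 3 can therefore be read: the limit of < 5000 nM in this assay, at which 3 of the 3 values shown sit.

Going by these compounds, how methyl, methoxy and dimethylamino compare in this read-out stays open.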